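Second heptyl chain on a diaminocyclitol aminoglycoside scaffold

The source may hold more compounds than are shown below. What is called first, only, known or untested is meant among the compounds shown, and "the series" means these compounds.

Measured compounds:
compound 1 `CCCCCCCCCCCO[C@@H]1[C@@H](O)[C@H](O[C@H]2O[C@H](CN)[C@@H](O)[C@H](O)[C@H]2N)[C@@H](N)C[C@H]1N`, 83.4%
compound 2 `NC[C@H]1O[C@H](O[C@H]2[C@H](O)[C@@H](O)[C@H](N)C[C@@H]2N)[C@H](N)[C@@H](OCCCc2ccc3ccccc3c2)[C@@H]1OCCCc1ccc2ccccc2c1`, 66.9%
compound 3 `CCCCCCCO[C@@H]1[C@@H](O)[C@H](O[C@H]2O[C@H](CN)[C@@H](O)[C@H](O)[C@H]2N)[C@@H](N)C[C@H]1N`, 71.3%

In an ADME assay on J774 cells (Mus musculus) for cytotoxicity, read by MTT assay, with a stated time of 24 h, tested at 30 uM (a lower number here means a stronger effect, a higher number a weaker effect of the compound at the concentration tested), compound 3 gives 71.3%, the second highest of the three numbers. Its nearest neighbour is compound 2, which in this assay gives 66.9%, a gap that lies within the scatter; its furthest is compound 1, which in this assay gives 83.4%, a gap beyond the scatter.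

Compound 4 `CCCCCCCO[C@@H]1[C@@H](N)[C@@H](O[C@H]2[C@H](O)[C@@H](OCCCCCCC)[C@H](N)C[C@@H]2N)O[C@H](CN)[C@H]1O` differs from compound 3 by heptyl in place of hydrogen on an oxygen on a saturated carbon, so a hydroxy of compound 3 becomes a heptyloxy. For the measured compounds named here, no measured pair shows exactly this change. Going by the values given here, the only single step available, a number 12.1 percentage points lower from compound 1 to compound 3 (beyond the scatter), concerns the length of the one chain already present rather than the addition of a second one. Compound 2, which carries two chains, gives the lowest of the three numbers, but its structure differs from compound 3 in more than one place.

Among the compounds with values here, with no direct precedent and only a modest chain-length step to lean on, the estimate for compound 4 is a number 9.3 percentage points lower from compound 3 to compound 4 (within the scatter), a moderate move towards a lower number. Compound 4 is therefore expected to give 62% in this assay, within a range from 45% to 80%.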

Compound 4, a percentage reported as activity, at one concentration (the size of the read-out at that concentration, not a potency): 79.9%
The estimate for compound 4 lay 17.9 percentage points below the measured number; the measured number falls inside the stated range.
By their numbers in this assay, from the lowest: compounds 2, 3, 4 and 1 (each within the scatter of the next, the first and the last beyond it).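

For the compounds shown here, at this oxygen on a saturated carbon, turning a hydroxy into a heptyloxy gives a number 8.6 percentage points higher from compound 3 to compound 4 (within the scatter) in this assay, so adding this second heptyl chain, with its 7 carbon atoms, produces no step that can be told from the usual spread of repeated measurements. Going by these compounds alone, the earlier compounds offered only a change of length in the one chain already present, a number 12.1 percentage points lower from compound 1 to compound 3 (beyond the scatter), and that step lies beyond the scatter, whereas this pair gives the first reading for a heptyl group placed at a second site on the shared core. Nothing available explains the cell read-out of compound 4 or why this addition leaves so small a step.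

Within the data shown here, the single pair leaves open whether the same small step would hold for a different group at this oxygen, such as a butyl chain, a longer chain of the length found in compound 1, or a heptyl chain ending in an amine or a carboxylic acid. It also leaves open how either heptyl chain of compound 4 contributes alone, since the effect of the added chain has been read against only one partner, compound 3.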